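The compounds below may be only part of what the source reports. "The series", "measured", "known", "first", "only" and "open" are said of these compounds alone.

Compound 1 `CC1=CC(=O)[C@]2(O1)C(=O)N[C@@](O)(CC(C)C)[C@@H]2O`, compound 2 `CC1=CC(=O)[C@@]2(O[C@H]2C(=O)CC(C)C)C(=O)N1` and compound 3 `CC1=CC(=O)[C@]2(O[C@@H]2C(=O)CC(C)C)C(=O)N1` were tested for their effect on the growth of a human cancer cell line in a functional assay on HeLa cells (Homo sapiens) for cytotoxicity, read by WST assay, with a stated time of 48 h; a lower number here means a stronger inhibitor, a higher number a weaker inhibitor. For compound 1 the assay reports only a limit, > 100000 nM. For compound 2 the entry reads "not determined" (no result reported). For compound 3 the entry likewise reads "not determined" (no result reported). Compound 3 therefore stands with no number of its own; of the other two results, one is a limit and the other is also no number. What can be said about compounds 2 and 3 is the fact that compounds 2 and 3 differ only in the configuration as drawn. The new compound, compound 4 `CC1=CC(=O)C2(OC2C(=O)CC(C)C)C(=O)N1`, differs from compound 3 in this way: the two compounds have the same atoms and bonds; at least one stereo element is drawn with a configuration in one of them and without one in the other: 2 of 2 stereo elements differ; a stereocentre at a saturated ring carbon is drawn S in compound 3 and without a configuration in compound 4; a stereocentre at a saturated ring carbon is drawn S in compound 3 and without a configuration in compound 4. Among the measured compounds shown here, no step between measured compounds is available here, so there is no measured change of any size to lean on, and no direction beyond the scatter can be claimed. Given (the limit of > 100000 nM in this assay, at which 1 of the 3 values shown sits), compound 4 is expected to show weak or no inhibition in this assay, with an estimated value around 100000 nM and a likely range from 20000 nM to 300000 nM.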

Compound 4, half-maximal inhibitory concentration: 40500 nM
Estimate against measurement, compound 4: 2.5-fold (0.39 log units) above; low and high end bracket the measured number.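

Among the compounds shown here, compound 2 and compound 3 have no number of their own in this assay, so the result for compound 4 gives no step to either of them. The compounds shown leave open whether the drawn configuration changes the effect on these cells.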